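Pyridin-2-yl for 4-fluorophenyl: expected tolerance in THP-1 cells

The source may report more compounds than this note shows. Statements on the series, on what has been measured and on what is new or still open speak of the compounds shown alone.

Compound 3 `COc1ccc(-c2cnc(NC(=O)c3ccc(F)cc3)n2C)cc1` carries a 4-fluorophenyl on the carbonyl carbon of its amide. In a toxicity assay on THP-1 cells (Homo sapiens) for inhibition (a lower number here means that less compound is tolerated, a higher number that more compound is tolerated), compound 3 gives only a limit, >= 50000 nM, not a number. Compound 1 `COc1ccc(-c2cnc(NC(=O)c3ccc(O)cc3)n2C)cc1` shares the same core, and in this assay compound 1 likewise gives only a limit, > 100000 nM. Compound 2 `COc1ccc(-c2cnc(NC(=O)c3cccc(C#N)c3)n2C)cc1` completes the trio, and in this assay compound 2 also gives only a limit, > 100000 nM. The three steps between them, a step that the two limits leave unreadable from compound 1 to compound 2, a step that the two limits leave unreadable from compound 1 to compound 3 and a step that the two limits leave unreadable from compound 2 to compound 3, cannot be read as sizes, because the limit of > 100000 nM in this assay, at which 2 of the 3 values shown sit, and the limit of >= 50000 nM in this assay, at which 1 of the 3 values shown sits, cap every value shown; compound 3 therefore stands at a limit among limits.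

Compound 4 `COc1ccc(-c2cnc(NC(=O)c3ccccn3)n2C)cc1` differs from compound 3 by pyridin-2-yl in place of 4-fluorophenyl on a carbonyl carbon. Among the measured compounds shown here, no measured step bears readably on this change, since each one joins two limits. The step from compound 3 to compound 4 in this assay is expected to be a step that the limit leaves unreadable from compound 3 to compound 4, that is, none beyond the scatter. Compound 4 is therefore estimated at 100000 nM in this assay, within 50000 nM to 200000 nM, most probably again reported only as a limit.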

Compound 4, half-maximal cytotoxic concentration: > 100000 nM
Compound 4: only a limit was reported; the forecaster's own chance of this, stated with the estimate: 80%; the middle value lies on the limit itself.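

Compound 4 gives only a limit in this assay, and its steps to compound 1, compound 2 and compound 3 cannot be read as sizes. The compounds shown leave open at what concentration any of the four harms these cells, and whether the group on the carbonyl carbon changes that.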